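This account rests on a few compounds, and the source may have more. Where it says the series, first, only, none or still open, it means among the compounds named here.

Within the data shown here, compound 1 `O=Cc1coc(C(=O)CCCCCCc2ccccc2)n1` is the only member of this small set with a definite number: in an assay on HEK-293T cells for inhibition of diacylglycerol lipase-alpha (Homo sapiens), read by colorimetric assay (a lower number here means a stronger inhibitor, a higher number a weaker inhibitor), compound 1 gives 1510 nM. Compound 2 `O=C(CCCCCCc1ccccc1)c1ncc(Cl)o1` reaches only a limit of the assay, > 10000 nM. Compound 3 `CSc1cnc(C(=O)CCCCCCc2ccccc2)o1` likewise ends at a limit, > 10000 nM. In other words, there is the limit of > 10000 nM in this assay, at which 2 of the 3 values shown sit, and compound 1 alone has a readable position. The steps of an at least 6.6-fold higher number from compound 1 to compound 2 (0.82 log units; beyond the scatter) and an at least 6.6-fold higher number from compound 1 to compound 3 (0.82 log units; beyond the scatter) both show what happens once the formyl group of compound 1 is exchanged, whereas the step that the two limits leave unreadable from compound 2 to compound 3 cannot be sized at all. Compound 4 `O=C(CCCCCCc1ccccc1)c1nc(-c2ccncc2)co1` differs from compound 1 by pyridin-4-yl in place of formyl on an aromatic carbon. Because an at least 6.6-fold higher number from compound 1 to compound 2 (0.82 log units; beyond the scatter) and an at least 6.6-fold higher number from compound 1 to compound 3 (0.82 log units; beyond the scatter) both carried the value out to the limit when the formyl group of compound 1 was replaced, a step of similar size toward a higher number in this assay is expected for compound 4 as well. The estimate for compound 4 is therefore 10000 nM, within a range of 3000 nM to 30000 nM, quite possibly reported only as a limit again. That expected change amounts to a 6.6-fold higher number from compound 1 to compound 4 (0.82 log units; beyond the scatter).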

Compound 4, half-maximal inhibitory concentration: > 10000 nM
Compound 4: a limit, no number; the forecaster's own chance of this, stated with the estimate: 60%; the middle value sits exactly at the limit.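

Compound 2 and compound 3 lost the formyl group and took a new group on another ring carbon, so they could not show what happens on the carbon that holds the formyl group in compound 1, next to the ring nitrogen. Compound 4 tests that carbon directly, and the swap from formyl to pyridin-4-yl gives an at least 6.6-fold higher number from compound 1 to compound 4 (0.82 log units; beyond the scatter), so a change confined to this one carbon is enough to lose the readable activity in this assay. Compound 4 itself gives only a limit, not a number, and it joins the others there: the limit of > 10000 nM in this assay, at which 3 of the 4 values shown sit.

As far as these compounds go, how much activity is lost therefore stays unknown, and compound 1 remains the only fixed point. Whether an amine, a carboxylic acid or a methyl ester on this same carbon would give a readable number is left open.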